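From 4-chlorophenyl to 3,5-dimethylphenyl on a sulfur

The source may report more compounds than this note shows. Statements on the series, on what has been measured and on what is new or still open speak of the compounds shown alone.

Of the compounds shown here, two sharing one core have been measured in a functional assay on A-375 cells (Homo sapiens) for inhibition, read by CCK-8 assay, with a stated time of 72 h, tested at 8 uM; on this read-out lower numbers stand for less inhibition of growth and higher numbers for more inhibition of growth at the one concentration tested. Compound 1 `Nc1ccccc1NC(=O)c1ccc(CSc2ccc(F)cc2)cc1` gives 54.3%. Compound 2 `Nc1ccccc1NC(=O)c1ccc(CSc2ccc(Cl)cc2)cc1` gives 48.6%, which lies within the scatter of the value for compound 1, so it cannot be separated from that compound on these numbers.

Compound 3 `Cc1cc(C)cc(SCc2ccc(C(=O)Nc3ccccc3N)cc2)c1` keeps the shared core and differs from compound 2 in the group on the sulfur: 3,5-dimethylphenyl in place of 4-chlorophenyl on a sulfur. Going by the values given here, only one measured step bears on this change, and it does so only in part. That step, with chloro in place of fluoro on an aromatic carbon, is a number 5.7 percentage points lower from compound 1 to compound 2 (within the scatter). Among the compounds with values here, the change to compound 3 replaces the whole group, and no compound measured so far carries a 3,5-dimethylphenyl group, so the data offer no direct guide. With so little evidence, no step beyond the scatter is expected, though the uncertainty is wide. The expected change is a number 1.4 percentage points higher from compound 2 to compound 3 (within the scatter). In this assay, the estimate for compound 3 is 50%, with an expected range of 35% to 65%.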

Compound 3, percent growth inhibition at one concentration: 74.7%
Estimate against measurement, compound 3: 24.7 percentage points below; measured number above the stated range.
By their numbers in this assay, from the lowest: compounds 2 and 1 (each within the scatter of the next); then compound 3.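

In this assay, the group on the sulfur proves able to shift the read-out beyond the scatter, which the exchange of one halogen for another on the phenyl ring did not do. Replacing the whole group gives a number 26.1 percentage points higher from compound 2 to compound 3 (beyond the scatter) and, with 3,5-dimethylphenyl in place of 4-fluorophenyl, a number 20.4 percentage points higher from compound 1 to compound 3 (beyond the scatter), so compound 3 stands clear of both earlier compounds at the one concentration tested. The counted features do not separate the groups, as each has one six-membered aromatic ring of carbon only, no hydrogen-bond donors or acceptors and no net charge, and no measurement shown here accounts for the rise.

From the compounds shown here alone, it remains open whether the higher number needs both methyl groups, as a phenyl ring carrying a single methyl group or no substituent at all would show, and whether larger groups such as ethyl or methoxy on the ring would carry it further. Also open, going by these compounds, is whether the result depends on the sulfur itself, which an oxygen or a methylene in its place would test, and how compound 3 behaves at other concentrations.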